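A few compounds are considered here, and "the series" means these few. Any claim that something is new, unique, unknown or untested is made for them only; others in the source may bear on it.

Working notes on the two measured anilino-substituted analogues sharing one core. Compound 1 `Cc1ccccc1Nc1ccc2c(c1)C(=O)N(C1CCC(=O)NC1=O)C2=O` carries a methyl on the aniline ring; in an assay on FRT-Jurkat cells for inhibition of nuclear factor NF-kappa-B complex (Homo sapiens), read by flow cytometry, with a stated time of 24 h, tested at 10 uM (on this read-out lower numbers stand for less inhibition and higher numbers for more inhibition at the one concentration tested (going by the name of the read-out)), compound 1 gives 2%. Compound 2 `CCOC(=O)c1ccc(Nc2ccc3c(c2)C(=O)N(C2CCC(=O)NC2=O)C3=O)cc1` instead carries an ethoxycarbonyl; in this assay compound 2 gives 5%. Within the data shown here, the two values lie within the usual scatter of each other, so compound 2 cannot be separated from compound 1 on these numbers: both read as essentially no inhibition at the single concentration tested, and no step between them can be stated.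

Compound 3 `CCc1ccc(Nc2ccc3c(c2)C(=O)N(C2CCC(=O)NC2=O)C3=O)cc1` is the next analogue, not yet measured. Its difference from compound 2 is ethyl in place of ethoxycarbonyl on an aromatic carbon. Both measured anilines sit at the floor of the read-out, and the change removes a group that did not lift compound 2 above compound 1 in this assay, so no step beyond the scatter is expected from compound 2 to compound 3, with the estimated step of a number 1 percentage points lower from compound 2 to compound 3 (within the scatter). Compound 3 is accordingly expected to give 4% in this assay, with a plausible range from -8% to 16%.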

Compound 3, a percentage reported as inhibition, at one concentration (the size of the read-out at that concentration, not a potency): 5%
Beside the measured number, compound 3's estimate is 1 percentage points below it, within the range that was stated.
By their numbers in this assay, from the lowest: compounds 1, 2 and 3 (each within the scatter of the next).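

Ethyl in place of ethoxycarbonyl on this aromatic carbon, para to a large group, gives in this assay no change at the digits printed from compound 2 to compound 3 (within the scatter) and so shows that, at this position, this read-out does not separate ethoxycarbonyl, with its double bond outside aromatic rings and its hydrogen-bond acceptors, from ethyl, which has neither. The aryl group on the nitrogen can also be exchanged without a step beyond the scatter: 4-ethylphenyl in place of 2-methylphenyl gives in this assay a number 3 percentage points higher from compound 1 to compound 3 (within the scatter) and leaves the three compounds unranked against one another. Nothing available here bears on why these numbers stand as they do.

Still open, as far as these compounds go, is whether any group at this position can give a value clearly beyond the scatter of these three, for example an amine, a carboxylic acid or a chain longer than ethyl. Also open is whether the shared core can show inhibition in this read-out at all when it carries an aryl group on the nitrogen, since the compounds shown offer no higher value to compare against.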